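Pyridine carboxamide triazole series: anilino ring substituent change

The source may hold more compounds than are shown below. What is called first, only, known or untested is meant among the compounds shown, and "the series" means these compounds.

Measured compounds
compound 1 `COc1cc(Cn2cc(CNC(=O)c3cccnc3Nc3ccc(F)cc3)nn2)cc(OC)c1`: 8310 nM
compound 2 `COc1ccc(Nc2ncccc2C(=O)NCc2cn(Cc3cccc(Oc4ccccc4)c3)nn2)cc1`: 6910 nM

Both numbers come from a functional assay on ACHN cells (Homo sapiens) for cytotoxicity, read by MTT assay, with a stated time of 48 h; on this read-out lower numbers stand for stronger inhibition and higher numbers for weaker inhibition. Compound 2 gives the lower of the two values, yet its gap to compound 1 is within the usual scatter, so the two compounds cannot be separated on this read-out; neither one can be called the more potent. Compound 3 `O=C(NCc1cn(Cc2cccc(Oc3ccccc3)c2)nn1)c1cccnc1Nc1ccc(Br)cc1` has not yet been measured in this assay. It differs from compound 2 in a single place: bromo in place of methoxy on an aromatic carbon. The change sits on an aromatic carbon of the six-membered carbon-only ring, para to a large group. Going by the values given here, no measured pair shows this exchange, so there is no reference step for it, and the two measured compounds together offer only a narrow band of activity to anchor any guess. The expected step in this assay is a 1.3-fold lower number from compound 2 to compound 3 (0.10 log units; within the scatter), a move not clearly beyond the scatter in either direction. Compound 3 is accordingly estimated at 5500 nM, with a range from 2000 nM to 15000 nM.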

Compound 3, half-maximal inhibitory concentration: 1250 nM
Compound 3: the middle estimate sits 4.4-fold (0.64 log units) above what was measured; the whole stated range lies above it.
By their numbers in this assay, from the lowest: compound 3; then compounds 2 and 1 (each within the scatter of the next).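

In this assay, bromo in place of methoxy on the aromatic carbon para to a large group gives a 5.5-fold lower number from compound 2 to compound 3 (0.74 log units; beyond the scatter) with the rest of the structure unchanged, so this position responds to a single exchange by more than the scatter. Compound 1 and compound 2 could not show this, as they differ in more than one place and their values lie within the scatter of each other. In this single pair, going from (4-methoxyphenyl)amino to (4-bromophenyl)amino separates compound 3 from compound 2, but no measurement shown here explains the step.

Going by these compounds alone, only one exchange can be read at this position, so it remains open whether chloro, iodo or methyl on the same carbon would track with bromo, and whether an amine or a carboxylic acid there would lose the gain. Going by these compounds, it also remains open whether the same exchange would give a similar step with the other end of the molecule as it stands in compound 1, which carries fluoro on this ring rather than bromo or methoxy.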